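Cyclobutyl for Cyclopentyl: Expected Effect on Receptor Activation

The source may hold more compounds than are shown below. What is called first, only, known or untested is meant among the compounds shown, and "the series" means these compounds.

Of the compounds shown here, three built on a shared core have been tested in a functional assay on HEK293 cells for activation of melanin-concentrating hormone receptor 1 (Homo sapiens), read by inositol phosphate accumulation; on this read-out lower numbers stand for an effect already at smaller amounts and higher numbers for an effect only at larger amounts of compound. Compound 1 `CC(C)(C)c1cc(N)c2cc(NC(=O)/C=C/c3ccc(C(F)(F)F)cc3)ccc2n1` gives 29 nM. Compound 2 `Nc1cc(C2CCCC2)nc2ccc(NC(=O)/C=C/c3ccc(C(F)(F)F)cc3)cc12` gives 68 nM, and compound 3 `CCCc1cc(N)c2cc(NC(=O)/C=C/c3ccc(CC)cc3)ccc2n1` gives 160 nM. Compound 2 thus holds the second highest of the three numbers: compound 1 is its nearest neighbour with a lower number, and compound 3 lies furthest from it with a higher number.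

Among the compounds with values here, only one pair of measured compounds differs in a single place. That step is a 2.3-fold higher number from compound 1 to compound 2 (0.37 log units; beyond the scatter), brought about by cyclopentyl in place of tert-butyl on an aromatic carbon.

Compound 4 `Nc1cc(C2CCC2)nc2ccc(NC(=O)/C=C/c3ccc(C(F)(F)F)cc3)cc12` differs from compound 2 by cyclobutyl in place of cyclopentyl on an aromatic carbon. The step from compound 1 to compound 2 is the one that bears on this change, since it also exchanges the alkyl group at the same aromatic carbon, and it was modest. Removing one carbon from the ring is a smaller alteration than that exchange, so the expected step in this assay is small, with a slight lean toward a lower number, and may well stay within the scatter, giving a 1.2-fold lower number from compound 2 to compound 4 (0.09 log units; within the scatter). Compound 4 is therefore estimated at 55 nM, within a range of 25 nM to 140 nM.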

Compound 4, half-maximal effective concentration: 250 nM
The estimate for compound 4 lay 4.5-fold (0.66 log units) below the measured number; measured number above the stated range.
By their numbers in this assay, from the lowest: compound 1; then compound 2; then compounds 3 and 4 (each within the scatter of the next).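

In this assay, the position next to the ring nitrogen proves sensitive to a change within the ring itself: a 3.7-fold higher number from compound 2 to compound 4 (0.57 log units; beyond the scatter) comes from cyclobutyl in place of cyclopentyl, so the four-membered and five-membered rings are not interchangeable here, even though the two groups differ by only one carbon and neither carries a hydrogen-bond donor or acceptor. Taken against the tert-butyl group, an 8.6-fold higher number from compound 1 to compound 4 (0.94 log units; beyond the scatter) is the widest gap yet seen among the compounds that differ only at this carbon, and the three groups now stand in the order tert-butyl, cyclopentyl, cyclobutyl, from the lowest number to the highest. Nothing available explains why the smaller ring gives the higher number. Whether the number keeps changing with ring size remains open, since a cyclopropyl or cyclohexyl ring at this carbon is not among the compounds shown. Open chains such as isopropyl or a longer alkyl chain are also absent, so it cannot be said whether the ring itself matters or only the shape of the alkyl group.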